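The source may hold more compounds than are shown below. What is called first, only, known or untested is meant among the compounds shown, and "the series" means these compounds.

Compound 1 `Cc1ccccc1-c1nn(-c2ccc(F)cc2F)cc1CNCCN1CCCCC1` is tested in an ADME assay on Huh-7 cells (Homo sapiens) for cytotoxicity (on this read-out lower numbers stand for higher toxicity in this test and higher numbers for lower toxicity in this test), and gives > 20000 nM; this is a limit of the assay, not a number. Compound 2 `Cc1ccccc1-c1nn(-c2ccc(F)cc2)cc1CNCCN1CCN(C)CC1` likewise gives > 20000 nM, again a limit. Among the measured compounds shown here, compound 3 `Cc1ccccc1-c1nn(-c2cccc(C(F)(F)F)c2)cc1CNCCN1CCN(C)CC1` gives 18000 nM, the one number in the set, reached by an at least 1.1-fold lower number from compound 2 to compound 3 (0.04 log units; that floor lies within the scatter). Two of the three results sit at the limit of > 20000 nM in this assay, at which 2 of the 3 values shown sit, so compound 1 stands where most of the series stands.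

Compound 4 `Cc1ccccc1-c1nn(-c2ccc(F)cc2F)cc1CNCc1ccncc1` differs from compound 1 by pyridin-4-yl in place of (piperidin-1-yl)methyl on a saturated chain carbon bound to an amine nitrogen. For the measured compounds named here, no measured step touches this part of the molecule; the single step from compound 2 to compound 3 changes the aryl on the aromatic nitrogen and stays within scatter. No step beyond the scatter is therefore expected, and compound 4 is estimated at 20000 nM (range 10000 nM to 40000 nM), i.e. an expected a number no higher from compound 1 to compound 4 (the limit leaves the size open).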

Compound 4, half-maximal cytotoxic concentration: > 20000 nM
Compound 4 gave a limit, no number (the forecaster's own chance of this, stated with the estimate: 60%); the middle value sits exactly at the limit.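

No step can be read from compound 1 to compound 4, since both results are limits: the limit of > 20000 nM in this assay, at which 3 of the 4 values shown sit.

What the compounds shown leave open is whether pyridin-4-yl in place of (piperidin-1-yl)methyl changes the half-maximal cytotoxic concentration at all.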